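A few compounds are considered here, and "the series" means these few. Any claim that something is new, unique, unknown or untested is made for them only; others in the source may bear on it.

Compound 1 `O=C(/C=C/c1cccc([N+](=O)[O-])c1)NNC(=O)c1ccc2c(c1)OCCO2`: 323000 nM in an ADME assay on cells (Macrophage) for cytotoxicity, read by MTT assay, with a stated time of 24 h; a lower number here means that less compound is tolerated, a higher number that more compound is tolerated
Compound 2 `O=C(/C=C/c1cccc(Cl)c1)NNC(=O)c1ccc2c(c1)OCCO2`: 391000 nM
Compound 3 `O=C(/C=C/c1ccc(F)cc1)NNC(=O)c1ccc2c(c1)OCCO2`: 319000 nM

Compound 3 gives the lowest of the three numbers in this assay, yet its nearest neighbour is compound 1, a step of a 1.0-fold lower number from compound 1 to compound 3 (0.01 log units; within the scatter), and its furthest is compound 2, a step of a 1.2-fold lower number from compound 2 to compound 3 (0.09 log units; within the scatter), so all three stand together within the scatter. Compound 4 `O=C(/C=C/c1ccccc1[N+](=O)[O-])NNC(=O)c1ccc2c(c1)OCCO2` has not yet been measured. It differs from compound 3 in one place: 2-nitrophenyl in place of 4-fluorophenyl on a double-bonded chain carbon bound to a double-bonded chain carbon. Going by the values given here, three measured steps bear on such exchanges of this group. Chloro in place of nitro gave a 1.2-fold higher number from compound 1 to compound 2 (0.08 log units; within the scatter), 4-fluorophenyl in place of 3-nitrophenyl gave a 1.0-fold lower number from compound 1 to compound 3 (0.01 log units; within the scatter), and 4-fluorophenyl in place of 3-chlorophenyl gave a 1.2-fold lower number from compound 2 to compound 3 (0.09 log units; within the scatter). None of them moved the number beyond the scatter, and compound 1 already carries a nitro group at 323000 nM, so for compound 4 no step beyond the scatter is expected in this assay. The estimate for compound 4 is 330000 nM, within 200000 nM to 550000 nM, which corresponds to an expected step of a 1.0-fold higher number from compound 3 to compound 4 (0.01 log units; within the scatter).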

Compound 4, half-maximal cytotoxic concentration: 257000 nM
For compound 4 the middle estimate is 1.3-fold (0.11 log units) above the measured one; measured number inside the range.
By their numbers in this assay, from the lowest: compounds 4, 3, 1 and 2 (each within the scatter of the next).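

Going by these compounds alone, on a double-bonded chain carbon bound to a double-bonded chain carbon, in this assay, 2-nitrophenyl in place of 3-nitrophenyl gave a 1.3-fold lower number from compound 1 to compound 4 (0.10 log units; within the scatter), so the first pair of compounds differing only in where the nitro group sits on the ring shows no change beyond the scatter. Within the data shown here, the same 2-nitrophenyl group in place of 4-fluorophenyl gave a 1.2-fold lower number from compound 3 to compound 4 (0.09 log units; within the scatter), and in place of 3-chlorophenyl it gave a 1.5-fold lower number from compound 2 to compound 4 (0.18 log units; within the scatter), the largest step at this position so far but still within the scatter. Nothing available accounts for this sameness among the four compounds.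

Going by these compounds, all four carry a phenyl ring with a single fluoro, chloro or nitro group, so it remains open whether an amine or a carboxylic acid on that ring would move the number beyond the scatter. Also open, on these data alone, is what a longer chain in place of the ring would do.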